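Swapping a hydroxy for an amino on the side chain

This account rests on a few compounds, and the source may have more. Where it says the series, first, only, none or still open, it means among the compounds named here.

In a functional assay on HT cells (Homo sapiens) for antiproliferative activity, read by fluorescence, with a stated time of 72 h (on this read-out higher numbers stand for weaker inhibition of growth and lower numbers for stronger inhibition of growth), compound 1 `CC(C)c1n[nH]c2c(NCc3ccc(-c4ccccn4)cc3)nc(SCCN)nc12` gives 22 nM. Compound 2 `CC(C)c1n[nH]c2c(NCc3ccc(-c4ccccn4)cc3)nc(SCCCO)nc12` gives 109 nM, and compound 3 `CC(C)c1n[nH]c2c(NCc3ccc(-c4ccccn4)cc3)nc(SCC(N)=O)nc12` gives 192 nM. Among these three numbers compound 2 stands second highest: the gap to compound 3 is small (a 1.8-fold higher number from compound 2 to compound 3 (0.25 log units; within the scatter)), while the gap the other way is clear (a 5.0-fold higher number from compound 1 to compound 2 (0.70 log units; beyond the scatter)). The unmeasured compound 4 `CC(C)c1n[nH]c2c(NCc3ccc(-c4ccccn4)cc3)nc(SCCCN)nc12` differs from compound 2 by amino in place of hydroxy on a saturated chain carbon, three bonds along the chain from a sulfur. Among the measured compounds shown here, the step that bears on this is the one from compound 1 to compound 2, in which the amino group was lost and the number rose; restoring an amino group is expected to roughly undo that rise, so the expected step is a 4.4-fold lower number from compound 2 to compound 4 (0.64 log units; beyond the scatter). Compound 4 is therefore estimated at about 25 nM, with a range from 10 nM to 70 nM.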

Compound 4, concentration for 50% growth inhibition: 120 nM
The estimate for compound 4 lay 4.8-fold (0.68 log units) below the measured number, and the stated range ends below it.
By their numbers in this assay, from the lowest: compound 1; then compounds 2, 4 and 3 (each within the scatter of the next).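

The amino group alone does not set the number here: in this assay, amino in place of hydroxy, three bonds along the chain from a sulfur, gives a 1.1-fold higher number from compound 2 to compound 4 (0.04 log units; within the scatter). Against the carbamoyl compound the picture is the same, with a 1.6-fold lower number from compound 3 to compound 4 (0.20 log units; within the scatter), whereas aminomethyl in place of amino, two bonds along the chain from a sulfur, gives a 5.5-fold higher number from compound 1 to compound 4 (0.74 log units; beyond the scatter), so among these compounds the low number goes with the 2-aminoethyl chain of compound 1 only. Nothing available explains this difference.

Still open, from the compounds shown here alone, is how a longer chain ending in an amine would behave, and whether a dimethylamino group on the 2-aminoethyl chain would keep the number of compound 1.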